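The source may report more compounds than this note shows. Statements on the series, on what has been measured and on what is new or still open speak of the compounds shown alone.

Compound 1 `Brc1cccc(Br)c1N(CC1CC1)C1=NCCN1` gives -1.12 in a physicochemical assay for lipophilicity; on this read-out higher numbers stand for higher lipophilicity and lower numbers for lower lipophilicity. Compound 2 `C/C=C/CN(C1=NCCN1)c1c(Br)cccc1Br` gives -0.49 in this assay, and compound 3 `CC(C)=CCN(C1=NCCN1)c1c(Br)cccc1Br` gives -0.14, the highest of the three numbers, standing a number 0.35 log units higher from compound 2 to compound 3 (beyond the scatter) and a number 0.98 log units higher from compound 1 to compound 3 (beyond the scatter). Compound 4 `Brc1cccc(Br)c1N(Cc1cccs1)C1=NCCN1` differs from compound 3 in one place: thiophen-2-yl in place of 2-methylprop-1-en-1-yl on a saturated chain carbon bound to a nitrogen on an aromatic ring. Among the measured compounds shown here, no measured step brings in an aromatic ring, so none matches this change directly; the steps that bear on it, a number 0.63 log units higher from compound 1 to compound 2 (beyond the scatter), a number 0.98 log units higher from compound 1 to compound 3 (beyond the scatter) and a number 0.35 log units higher from compound 2 to compound 3 (beyond the scatter), are all modest and all in the direction of compound 3. For compound 4 a small step is expected, a number 0.11 log units lower from compound 3 to compound 4 (within the scatter), with its direction uncertain. Compound 4 is therefore estimated at -0.25, within a range from -0.75 to 0.25.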

Compound 4, distribution coefficient: -0.1
Compound 4: the middle estimate sits 0.15 log units below what was measured; the measured number falls inside the stated range.
By their numbers in this assay, from the lowest: compound 1; then compound 2; then compounds 3 and 4 (each within the scatter of the next).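

Read in this assay an aromatic ring on this chain carbon, thiophen-2-yl in place of 2-methylprop-1-en-1-yl, gives a number 0.04 log units higher from compound 3 to compound 4 (within the scatter) and so cannot be told apart from the open-chain alkene here. Set against the other groups, thiophen-2-yl gives a number 0.39 log units higher from compound 2 to compound 4 (beyond the scatter) and a number 1.02 log units higher from compound 1 to compound 4 (beyond the scatter) as the only large step in the series. No measurement shown accounts for these steps. On these data alone, whether phenyl or furan-2-yl on this carbon would stay level with compound 3 remains open. So does the outcome for an amine or a carboxylic acid carried on the chain.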